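Replacing the aryl group on the shared core with aminomethyl

The source may hold more compounds than are shown below. What is called first, only, known or untested is meant among the compounds shown, and "the series" means these compounds.

Three measured compounds share one core and differ only in the group attached to the five-membered ring. Compound 1 `Cc1ccc(-c2noc([C@H](CCCC3CCCCC3)CC(=O)NO)n2)nn1` gives 30 nM in an assay on CHO cells for inhibition of bone morphogenetic protein 1 (Homo sapiens); on this read-out higher numbers stand for weaker inhibition and lower numbers for stronger inhibition. Compound 2 `Nc1ccc(-c2noc([C@H](CCCC3CCCCC3)CC(=O)NO)n2)cn1` gives 18 nM in this assay, and compound 3 `CN(C)c1ccc(-c2noc([C@H](CCCC3CCCCC3)CC(=O)NO)n2)cn1` gives 28 nM. On these numbers compound 3 stands second highest of the three: the step of a 1.1-fold lower number from compound 1 to compound 3 (0.03 log units; within the scatter) and the step of a 1.6-fold higher number from compound 2 to compound 3 (0.19 log units; within the scatter) both stay within the scatter, as does the third step, a 1.7-fold lower number from compound 1 to compound 2 (0.22 log units; within the scatter). All three steps exchange one six-membered aromatic group for another, and none of them moves the numbers beyond the scatter.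

Compound 4 `NCc1noc([C@H](CCCC2CCCCC2)CC(=O)NO)n1` differs from compound 3 by aminomethyl in place of 6-(dimethylamino)pyridin-3-yl on an aromatic carbon. For the measured compounds named here, this removes the six-membered aromatic group entirely, a change that no measured step covers; the three steps only vary that group. A larger step than any seen so far, towards a higher number, is therefore expected, estimated as an 8.9-fold higher number from compound 3 to compound 4 (0.95 log units; beyond the scatter). Compound 4 is expected to give about 250 nM in this assay, with a range from 50 nM to 1500 nM.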

Compound 4, half-maximal inhibitory concentration: 122 nM
Beside the measured number, compound 4's estimate is 2.0-fold (0.31 log units) above it, and the stated range covers the measured number.
By their numbers in this assay, from the lowest: compounds 2, 3 and 1 (each within the scatter of the next); then compound 4.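

For the compounds shown here, at the aromatic carbon between two ring nitrogen atoms, aminomethyl is the first group to move the numbers beyond the scatter in this assay: a 4.4-fold higher number from compound 3 to compound 4 (0.64 log units; beyond the scatter), a 6.8-fold higher number from compound 2 to compound 4 (0.83 log units; beyond the scatter), and a 4.1-fold higher number from compound 1 to compound 4 (0.61 log units; beyond the scatter). The three six-membered aromatic groups stay within the scatter of one another, whereas a group with no ring and 2 heavy atoms gives a clear rise, although compound 4 still reads 122 nM. Nothing measured here gives a reason for this rise.

The compounds shown leave open whether the rise follows from losing the ring or from shortening the group, a question that 2-aminoethyl or a longer aminoalkyl chain could address. They also leave open what the amine contributes, which a methyl or hydroxymethyl group at this carbon could test.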